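Acetamido Added to the Shared Core: Expected Liver-Cell Cytotoxicity

A few compounds are considered here, and "the series" means these few. Any claim that something is new, unique, unknown or untested is made for them only; others in the source may bear on it.

Compound 1, `COc1cc2ccc(=O)oc2cc1OCCOc1no[n+]([O-])c1S(=O)(=O)c1ccccc1`: 10900 nM
Compound 2, `COc1cc2ccc(=O)oc2cc1OCCCOc1no[n+]([O-])c1S(=O)(=O)c1ccccc1`: 7820 nM

In an ADME assay on L02 cells (Homo sapiens) for cytotoxicity, read by MTT assay, with a stated time of 48 h (on this read-out lower numbers stand for stronger inhibition and higher numbers for weaker inhibition), compound 1 gives 10900 nM and compound 2 gives 7820 nM; the two numbers lie within the usual scatter of each other, so neither can be told apart from the other. Compound 3, `COc1cc2cc(NC(C)=O)c(=O)oc2cc1OCCCOc1no[n+]([O-])c1S(=O)(=O)c1ccccc1`, is not yet measured in this assay. It differs from compound 2 in one place: acetamido in place of hydrogen on an aromatic carbon. Going by the values given here, no measured pair shows the effect of such a change, so no step beyond the scatter is expected in either direction. Compound 3 is therefore estimated at 8000 nM, between 3000 nM and 25000 nM, an expected step of a 1.0-fold higher number from compound 2 to compound 3 (0.01 log units; within the scatter).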

Compound 3, half-maximal inhibitory concentration: 8360 nM
Compound 3: the middle estimate sits 1.0-fold (0.02 log units) below what was measured, and the stated range covers the measured number.
By their numbers in this assay, from the lowest: compounds 2, 3 and 1 (each within the scatter of the next).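

In this assay, acetamido in place of hydrogen on this aromatic carbon, two atoms from the ring oxygen, gives a 1.1-fold higher number from compound 2 to compound 3 (0.03 log units; within the scatter). Going by these compounds alone, this is the first direct look at this position, and it shows that the carbon can carry acetamido with no change in liver-cell cytotoxicity that can be told from repeat-measurement noise. Nothing measured here offers an explanation for this result. Going by these compounds, whether an amine or a carboxylic acid on this carbon would move the number beyond the scatter stays open, as does whether acetamido would act the same way on compound 1.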